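Moving the Methyl Around the Thiophene

The source may hold more compounds than are shown below. What is called first, only, known or untested is meant among the compounds shown, and "the series" means these compounds.

Of the compounds shown here, three have numbers so far. Compound 1 `O=C(/C=C/c1ccc(N2CCCCC2)cc1)c1ccc(I)s1` gives 22000 nM in an ADME assay on CCRF-CEM cells (Homo sapiens) for cytotoxicity, with a stated time of 5 days; a higher number here means a weaker inhibitor, a lower number a stronger inhibitor. Compound 2 `c1csc(C2=NNC(c3ccc(N4CCCCC4)cc3)C2)c1` gives 6900 nM in this assay, and compound 3 `Cc1ccsc1C1=NNC(c2ccc(N3CCCCC3)cc2)C1` gives 2300 nM. Among the measured compounds shown here, compound 3 therefore holds the lowest number of the three, beyond the scatter from both compound 2 and compound 1, and the step of a 3.0-fold lower number from compound 2 to compound 3 (0.48 log units; beyond the scatter) is the single one-place change recorded.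

Compound 4 `Cc1ccc(C2=NNC(c3ccc(N4CCCCC4)cc3)C2)s1` has not yet been measured. It differs from compound 3 in that (5-methylthiophen-2-yl in place of 3-methylthiophen-2-yl on a carbon with a double bond to nitrogen), so the two have the same atoms, joined differently. For the measured compounds named here, no recorded step bears directly on this change: the step from compound 2 to compound 3 adds a methyl rather than moving one, and it shows only that a methyl on the thiophene can lower the number modestly. With nothing to say which methyl position is favoured, a step within the scatter is expected, a 1.3-fold higher number from compound 3 to compound 4 (0.12 log units; within the scatter). Compound 4 is estimated at 3000 nM, with a range from 1000 nM to 10000 nM.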

Compound 4, half-maximal inhibitory concentration: 15300 nM
Compound 4: the middle estimate sits 5.1-fold (0.71 log units) below what was measured; measured number outside the range, above it.
By their numbers in this assay, from the lowest: compound 3; then compound 2; then compounds 4 and 1 (each within the scatter of the next).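

The position of the methyl on the thiophene matters in this assay: 5-methylthiophen-2-yl in place of 3-methylthiophen-2-yl gives a 6.7-fold higher number from compound 3 to compound 4 (0.82 log units; beyond the scatter) and so the two isomers cannot be treated as interchangeable. Adding a methyl does not lower the number in every case, since the step of a 3.0-fold lower number from compound 2 to compound 3 (0.48 log units; beyond the scatter) is reversed when the methyl enters as 5-methylthiophen-2-yl, which gives a 2.2-fold higher number from compound 2 to compound 4 (0.35 log units; beyond the scatter) and goes against the earlier direction. No measurement at hand accounts for this difference between the two methyl positions. The compounds shown leave open whether an ethyl, a chlorine or a methoxy on the thiophene would show the same split between the 3-substituted and 5-substituted forms. They also leave open whether the split would hold with another amine in place of the one on the shared core.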